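The compounds below may be only part of what the source reports. "The series", "measured", "known", "first", "only" and "open" are said of these compounds alone.

Measured so far in a functional assay on NCI-H460 cells (Homo sapiens) for inhibition, read by sulforhodamine B assay, with a stated time of 48 h; on this read-out higher numbers stand for weaker inhibition of growth and lower numbers for stronger inhibition of growth:
compound 1 `COc1cc(-c2nn(-c3cccc(NC(=O)c4cccc(C(F)(F)F)c4)c3)cc2-c2ccncc2)ccc1Cl`: 1450 nM
compound 2 `COc1cc(-c2nn(-c3cccc(NC(=O)Nc4ccc(Cl)c(Cl)c4)c3)cc2-c2ccncc2)ccc1Cl`: 1110 nM
compound 3 `COc1cc(-c2nn(-c3cccc(NC(=O)c4ccc(Cl)c(C(F)(F)F)c4)c3)cc2-c2ccncc2)ccc1Cl`: 3470 nM

Compound 3 gives the highest number of the three, so the weakest growth inhibition; its nearest neighbour is compound 1, with a 2.4-fold higher number from compound 1 to compound 3 (0.38 log units; beyond the scatter), and compound 2 is furthest, with a 3.1-fold higher number from compound 2 to compound 3 (0.50 log units; beyond the scatter). Compound 4 `COc1cc(-c2nn(-c3cccc(NC(=O)Nc4ccc(Cl)c(C(F)(F)F)c4)c3)cc2-c2ccncc2)ccc1Cl` differs from compound 3 by (4-chloro-3-(trifluoromethyl)phenyl)amino in place of 4-chloro-3-(trifluoromethyl)phenyl on a carbonyl carbon. The closest measured parallel is the same kind of swap, made with a different aryl group, from compound 1 to compound 2: a 1.3-fold lower number from compound 1 to compound 2 (0.12 log units; within the scatter), within the scatter. On that basis compound 4 is expected to show a 1.4-fold lower number from compound 3 to compound 4 (0.14 log units; within the scatter), at most a modest shift toward stronger inhibition. The estimate for compound 4 in this assay is 2500 nM, with a likely range from 1200 nM to 5200 nM.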

Compound 4, concentration for 50% growth inhibition: 1110 nM
Estimate against measurement, compound 4: 2.3-fold (0.35 log units) above, outside the stated range (below it).
By their numbers in this assay, from the lowest: compounds 2, 4 and 1 (each within the scatter of the next); then compound 3.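

With 4-chloro-3-(trifluoromethyl)phenyl on the carbonyl carbon, adding the amino link moves the number beyond the scatter (a 3.1-fold lower number from compound 3 to compound 4 (0.50 log units; beyond the scatter)), whereas the same kind of swap with a different aryl group stayed within it. The amino-linked compound 4 also sits within the scatter of compound 1 (a 1.3-fold lower number from compound 1 to compound 4 (0.12 log units; within the scatter)). On the amino-linked form, trifluoromethyl in place of chloro makes no visible difference (no change at the digits printed from compound 2 to compound 4 (within the scatter)).

Nothing shown explains why the swap matters more here. As far as these compounds go, whether a nitrile in place of that trifluoromethyl would give a similar number stays open.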